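Moving a Sulfamoyl Group on an Anilide Cytotoxicity Series

A few compounds are considered here, and "the series" means these few. Any claim that something is new, unique, unknown or untested is made for them only; others in the source may bear on it.

Compound 1 `CC(C)n1ncc2c(C(=O)Nc3ccc(F)cc3)cc(-c3cccs3)nc21` was examined in an ADME assay on LLC-MK2 cells (Macaca mulatta) for cytotoxicity, read by spectrophotometry and crystal violet staining, with a stated time of 4 days; on this read-out lower numbers stand for higher toxicity in this test and higher numbers for lower toxicity in this test. Compound 1 gives > 200000 nM, which is a limit of the assay rather than a number, sitting at the limit of > 200000 nM in this assay, at which 1 of the 2 values shown sits. Compound 2 `CC(C)n1ncc2c(C(=O)Nc3ccc(F)c(S(N)(=O)=O)c3)cc(-c3cccs3)nc21` gives 50000 nM in this assay. Among the measured compounds shown here, the single change between them is an at least 4.0-fold lower number from compound 1 to compound 2 (0.60 log units; beyond the scatter). Compound 3 `CC(C)n1ncc2c(C(=O)Nc3ccccc3S(N)(=O)=O)cc(-c3cccs3)nc21` has not yet been measured in this assay. Relative to compound 1, the change is 2-sulfamoylphenyl in place of 4-fluorophenyl on an amide-type nitrogen. For the measured compounds named here, the one measured step that bears on this, the one from compound 1 to compound 2, also brought a sulfamoyl group onto the ring carried by the amide-type nitrogen, and it lowered the number beyond the scatter. A step of similar direction and size is therefore expected, an at least 3.3-fold lower number from compound 1 to compound 3 (0.52 log units; beyond the scatter). For compound 3 the expected value in this assay is estimated at 60000 nM, within a range from 20000 nM to 200000 nM.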

Compound 3, half-maximal cytotoxic concentration: 25000 nM
Estimate against measurement, compound 3: 2.4-fold (0.38 log units) above; the measured number falls inside the stated range.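

In this assay the change is not confined to a single compound. Placing 2-sulfamoylphenyl instead of 4-fluorophenyl on the amide-type nitrogen gives an at least 8.0-fold lower number from compound 1 to compound 3 (0.90 log units; beyond the scatter). Compound 2 and compound 3 thus both carry a sulfamoyl group on this ring, and both show a lower number, meaning higher toxicity in this test, than compound 1. The true size of the step stays unknown, since the value for compound 1 is a limit: the limit of > 200000 nM in this assay, at which 1 of the 3 values shown sits.

Compound 3 lacks the fluorine that compound 2 keeps, so these two differ in more than one place and cannot show what the site of the sulfamoyl group does by itself. On these data alone, whether a carboxylic acid or an amine on this ring would also lower the number remains open.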